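This account rests on a few compounds, and the source may have more. Where it says the series, first, only, none or still open, it means among the compounds named here.

Compound 2 `O=C(Nc1ccc(Cl)c(-c2nnc3c(Cl)cccn23)c1)c1c(F)cccc1Cl` is one of three close analogues built on one shared core. In a functional assay on AN3-CA cells (Homo sapiens) for antiproliferative activity, read by MTT assay, with a stated time of 72 h (on this read-out lower numbers stand for stronger inhibition and higher numbers for weaker inhibition), compound 2 gives > 100000 nM, which is a limit of the assay rather than a measured number. Compound 1 `CS(=O)(=O)c1ccc(C(=O)Nc2ccc(Cl)c(-c3nnc4c(Cl)cccn34)c2)c(Cl)c1` sits at the same point: in this assay compound 1 gives > 100000 nM, again only a limit. Compound 3 `O=C(Nc1ccc(Cl)c(-c2nnc3c(Cl)cccn23)c1)c1ccon1` behaves the same way, returning in this assay > 100000 nM, a limit as well. The one single-point step among these three, a step that the two limits leave unreadable from compound 2 to compound 3, therefore cannot be read, the reason being (the limit of > 100000 nM in this assay, at which 3 of the 3 values shown sit). Compound 4 `CS(=O)(=O)c1ccc(C(=O)Nc2ccc(Cl)c(-c3nnc4c(Cl)cccn34)c2)cc1` differs from compound 2 by 4-(methylsulfonyl)phenyl in place of 2-chloro-6-fluorophenyl on a carbonyl carbon. Going by the values given here, no measured step bears directly on this change, and the only related step is unreadable, so no step beyond the scatter can be anticipated in either direction. Compound 4 is accordingly expected to give about 100000 nM in this assay, within 30000 nM to 300000 nM, most probably reported once more as a limit. The expected step of a number no higher from compound 2 to compound 4 (the limit leaves the size open) is thus essentially flat.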

Compound 4, half-maximal inhibitory concentration: > 100000 nM
Compound 4 gave a limit, no number; the forecaster's own chance of this, stated with the estimate: 80%; the middle value lies on the limit itself.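

No new step can be read between compound 4 and compound 1, compound 2 or compound 3, because all four share one limit rather than a number: the limit of > 100000 nM in this assay, at which 4 of the 4 values shown sit.

The compounds shown leave open whether any of these changes, on the carbonyl carbon or on the aromatic carbon, alters antiproliferative activity at all.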